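Working notes on the series: from compound 3 to compound 4

This account rests on a few compounds, and the source may have more. Where it says the series, first, only, none or still open, it means among the compounds named here.

Measured so far in a functional assay on U-87MG ATCC cells for antiproliferative activity against U-87 MG (Homo sapiens), read by MTT assay, with a stated time of 48 h, tested at 100 uM; a lower number here means a stronger effect, a higher number a weaker effect of the compound at the concentration tested:
compound 1 `COc1ccc(-c2nc(C)c(C(=O)CSc3nc(N)c(C#N)c(-c4ccc(Cl)cc4)n3)s2)cc1`: 3.9%
compound 2 `COc1ccc(-c2nc(C)c(C(=O)CSc3nc(N)c(C#N)c(-c4ccccc4)n3)s2)cc1`: 5.25%
compound 3 `COc1ccc(-c2nc(C)c(C(=O)CSc3nc(-c4ccc(Cl)cc4)c(C#N)c(=O)[nH]3)s2)cc1`: 2.85%

Compound 3 carries the smallest of the three numbers in this assay, but its gap to compound 1 and its gap to compound 2 are each within the scatter, so no order among the three is claimed. Going by the values given here, the only single-point step measured in the set, a number 1.4 percentage points higher from compound 1 to compound 2 (within the scatter), is also within the scatter; it replaces a chloro on an aromatic carbon with hydrogen and it leaves the read-out essentially where it was.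

Compound 4 `COc1ccc(-c2nc(C)c(C(=O)CSc3nc(-c4ccc(OC)c(OC)c4)c(C#N)c(=O)[nH]3)s2)cc1` differs from compound 3 in one place: 3,4-dimethoxyphenyl in place of 4-chlorophenyl on an aromatic carbon. Among the compounds with values here, no measured pair in the set exchanges a 4-chlorophenyl for a 3,4-dimethoxyphenyl, so the step from compound 1 to compound 2 is the only guide, and it bears on the change only loosely, as a different alteration of the same aryl group. Given that the one comparable step stayed within the scatter, a step from compound 3 to compound 4 beyond the scatter in either direction is not expected; the expected step is a number 1.7 percentage points higher from compound 3 to compound 4 (within the scatter). Compound 4 is therefore estimated at 4.5% in this assay, with a range from 1% to 14%.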

Compound 4, a percentage reported as activity, at one concentration (the size of the read-out at that concentration, not a potency): 5.39%
The estimate for compound 4 lay 0.9 percentage points below the measured number; the measured number falls inside the stated range.
By their numbers in this assay, from the lowest: compounds 3, 1, 2 and 4 (each within the scatter of the next).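

In this assay, the exchange on this aromatic carbon, next to the ring nitrogen and ortho to a cyano group, gives a number 2.5 percentage points higher from compound 3 to compound 4 (within the scatter). The earlier step on this aryl group only removed a chloro, whereas this one brings in a larger group, with 10 heavy atoms against 7 and 2 hydrogen-bond acceptors against 0, and the read-out still does not separate from that of compound 3; at this position, then, the 4-chlorophenyl can give way to the 3,4-dimethoxyphenyl without a change beyond the scatter. No accompanying measurement speaks to the origin of this result.

As far as these compounds go, whether an amine or a carboxylic acid on the phenyl ring, or a longer alkoxy chain in place of a methoxy, would move the read-out beyond the scatter stays open. Also open, from the compounds shown here alone, is how compounds 3 and 4 would separate at lower concentrations, as a read-out at a single concentration gives no potency.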